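This account rests on a few compounds, and the source may have more. Where it says the series, first, only, none or still open, it means among the compounds named here.

Compound 1, `CCCCCCCCCCCC(=O)OC[C@H](CSC[C@@H](N)C(=O)NC1(CO)CC1)OC(=O)CCCCCCCCCCC`, gives 265 nM in an assay on HEK293 cells for agonist activity at Toll-like receptor 2 (Homo sapiens); on this read-out lower numbers stand for an effect already at smaller amounts and higher numbers for an effect only at larger amounts of compound. Compound 2, `CCCCCCCCCCCC(=O)OC[C@H](CSC[C@@H](N)C(=O)NCCOCCOS(=O)(=O)O)OC(=O)CCCCCCCCCCC`, gives 61 nM in this assay. Compound 3, `CCCCCCCCCCCC(=O)OC[C@H](CSC[C@@H](N)C(=O)NC(CC)COC)OC(=O)CCCCCCCCCCC`, gives 71.8 nM in this assay.

Compound 3 holds the second highest of the three numbers. Its nearest neighbour is compound 2, with a 1.2-fold higher number from compound 2 to compound 3 (0.07 log units; within the scatter); its furthest is compound 1, with a 3.7-fold lower number from compound 1 to compound 3 (0.57 log units; beyond the scatter). The third step is a 4.3-fold lower number from compound 1 to compound 2 (0.64 log units; beyond the scatter).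

Compound 4, `CCCCCCCCCCCC(=O)OC[C@H](CSC[C@@H](N)C(=O)NCCN)OC(=O)CCCCCCCCCCC`, differs from compound 3 by 2-aminoethyl in place of 1-(methoxymethyl)propyl on an amide-type nitrogen. All three measured steps change the group on this same nitrogen: two of them, both starting from compound 1, were modest, and the swap from compound 2 to compound 3 stayed within the scatter. The expectation for this assay is therefore a 1.0-fold higher number from compound 3 to compound 4 (0.02 log units; within the scatter), no step beyond the scatter. Compound 4 is estimated at 75 nM, within a range of 25 nM to 220 nM.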

Compound 4, half-maximal effective concentration: 5240 nM
For compound 4 the middle estimate is 70-fold (1.84 log units) below the measured one; measured number outside the range, above it.
By their numbers in this assay, from the lowest: compounds 2 and 3 (each within the scatter of the next); then compound 1; then compound 4.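

In this assay the group on this amide-type nitrogen proves able to move the number much further than the earlier swaps did: 2-aminoethyl brings a 73-fold higher number from compound 3 to compound 4 (1.86 log units; beyond the scatter) and an 86-fold higher number from compound 2 to compound 4 (1.93 log units; beyond the scatter) and a 20-fold higher number from compound 1 to compound 4 (1.30 log units; beyond the scatter) so the step is large from all three other compounds. The position therefore does not accept every group alike, although the three earlier groups stayed no more than modestly apart. Nothing measured here explains this step. From the compounds shown here alone, whether it follows the terminal amine or the smaller group remains open; 3-aminopropyl, 2-hydroxyethyl or 2-methoxyethyl on the same nitrogen could separate the two.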